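The compounds below may be only part of what the source reports. "The series", "measured", "known", "first", "only" and "open" are said of these compounds alone.

- Compound 1 `C=CC(=O)Nc1cc(Nc2ncc(F)c(Nc3ccccc3S(=O)(=O)C(C)C)n2)c(OC)cc1N(C)CCN(C)C`: 26%
- Compound 2 `C=CC(=O)Nc1cc(Nc2nccc(Nc3ccccc3S(=O)(=O)C(C)C)n2)c(OC)cc1N(C)CCN(C)C`: 5%

For the measured compounds named here, in an ADME assay on microsomes from liver (Homo sapiens) for metabolic stability, read by LC-MS, using NADPH, with a stated time of 30 min, tested at 1 uM (on this read-out lower numbers stand for a less stable compound and higher numbers for a more stable compound), compound 2 gives 5%, the lower of the two numbers measured so far, and its only neighbour, compound 1, gives 26%. Compound 3 `C=CC(=O)Nc1cc(Nc2ncc(I)c(Nc3ccccc3S(=O)(=O)C(C)C)n2)c(OC)cc1N(C)CCN(C)C` has not been measured. It differs from compound 2 by one change: iodo in place of hydrogen on an aromatic carbon. Going by the values given here, one measured step bears on this, a number 21 percentage points lower from compound 1 to compound 2 (beyond the scatter), where hydrogen takes the place of fluoro on the same aromatic carbon. The new change runs the opposite way, with hydrogen leaving, so a rise is expected in this assay. However, fluoro is not iodo, and no measured compound carries iodo, so this single step is only a loose guide. The expected change is a number 15 percentage points higher from compound 2 to compound 3 (beyond the scatter). For compound 3, the estimated value is 20%, with an expected range from 5% to 45%.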

Compound 3, percent of the compound remaining: 14%
For compound 3 the middle estimate is 6 percentage points above the measured one; low and high end bracket the measured number.
By their numbers in this assay, from the lowest: compounds 2 and 3 (each within the scatter of the next); then compound 1.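

In this assay the swap of hydrogen for iodo on this aromatic carbon gives a number 9 percentage points higher from compound 2 to compound 3 (within the scatter) and so cannot be told apart from no change at all. Replacing fluoro by iodo at the same place gives a number 12 percentage points lower from compound 1 to compound 3 (beyond the scatter) and shows that these two halogens do not behave alike here, so the higher number seen with fluoro does not simply extend to any halogen on this carbon. Nothing at hand says why the two halogens part ways.

On these data alone, whether chloro, bromo, a methyl group or a nitrile on this carbon would sit with fluoro or with hydrogen and iodo in this assay remains open. So does whether the gap between fluoro and iodo would hold if the rest of the molecule were different.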